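The source may hold more compounds than are shown below. What is called first, only, known or untested is meant among the compounds shown, and "the series" means these compounds.

Measured compounds and their values:

Compound 1 `ClCc1cccc(Cn2cnc3c(Cl)ncnc32)c1`: 67600 nM
Compound 2 `ClCc1cccc(Cn2cnc3c(Cl)nc(Cl)nc32)c1`: 55000 nM
Compound 3 `ClCc1ccccc1Cn1cnc2ncnc(Cl)c21`: 74100 nM

All three were tested in a functional assay on PC-3 cells (Homo sapiens) for cytotoxicity, read by sulforhodamine B assay, with a stated time of 48 h; a lower number here means that less compound is tolerated, a higher number that more compound is tolerated. Compound 2 sits alongside compound 1 and compound 3 on this assay: its gap to either of them is within the scatter of repeated measurements, so the three numbers cannot be told apart with confidence.

The unmeasured compound 4 `Nc1nc(Cl)c2ncn(Cc3cccc(CCl)c3)c2n1` differs from compound 2 in one place: amino in place of chloro on an aromatic carbon. Among the measured steps, only one bears on it at all, and only loosely. Among the measured compounds shown here, the step of a 1.2-fold lower number from compound 1 to compound 2 (0.09 log units; within the scatter) is the sole single-point change recorded, and it concerns a chloro entering rather than an amino, so it sets no precedent for the present change. For the measured compounds named here, the numbers of compound 2 and compound 3 show only that moving the chloromethyl group about on the benzyl ring leaves the read-out within the scatter. No measured compound carries an amino group, so the direction of the step from compound 2 to compound 4 rests on no shown data.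

Given how closely the three measured compounds cluster, compound 4 is expected to stay near them, with the step of a 1.2-fold higher number from compound 2 to compound 4 (0.07 log units; within the scatter) being the estimate, and no change beyond the scatter is foreseen. Compound 4 is therefore estimated at 65000 nM, with a range from 25000 nM to 170000 nM.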

Compound 4, concentration lethal to 50% of the cells: 63100 nM
Compound 4: middle estimate off by 1.0-fold (0.01 log units), on the high side; measured number inside the range.
By their numbers in this assay, from the lowest: compounds 2, 4, 1 and 3 (each within the scatter of the next).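

In this assay, the aromatic carbon between two ring nitrogen atoms can now be read with three different occupants on an otherwise shared structure: hydrogen in compound 1, chloro in compound 2 and amino in compound 4. Amino in place of chloro gives a 1.1-fold higher number from compound 2 to compound 4 (0.06 log units; within the scatter), and amino in place of hydrogen gives a 1.1-fold lower number from compound 1 to compound 4 (0.03 log units; within the scatter). The earlier compounds shown here showed this only for chloro against hydrogen, whereas the new pair of steps shows that a group bearing a hydrogen-bond donor at this place also gives a number that cannot be told apart from those of compound 1 and compound 2.

The compounds shown do not tell whether a bulkier amine such as dimethylamino or morpholine, a hydroxyl group or a methoxy group at this place would stay within the scatter, or whether amino would read the same on the structure of compound 3, which carries its chloromethyl group elsewhere on the benzyl ring. No evidence is available that would account for how closely these numbers lie.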